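The source may report more compounds than this note shows. Statements on the series, on what has been measured and on what is new or still open speak of the compounds shown alone.

In an assay on cells for antagonist activity at vitamin D3 receptor (Homo sapiens), read by a luciferase reporter (a higher number here means a weaker inhibitor, a lower number a stronger inhibitor), the measured compounds stand as follows.

Compound 1 `COC(=O)c1ccccc1OCc1oc(-c2ccccc2OC)nc1C`: 20200 nM
Compound 2 `COC(=O)c1cccc(OCc2oc(-c3ccccc3OC)nc2C)c1`: 7330 nM
Compound 3 `COc1ccccc1-c1nc(C)c(COc2ccccc2C(=O)O)o1`: > 80000 nM, which is a limit of the assay and not a number.

Compound 2 gives the lower of the two numbers, and compound 1 the higher; the difference between the two cores is not broken down here. Compound 3 follows from compound 1 by hydrogen in place of methyl on an oxygen next to a carbonyl group, and that change moved the number an at least 3.9-fold higher number from compound 1 to compound 3 (0.59 log units; beyond the scatter). Compound 3 sits at the limit of > 80000 nM in this assay, at which 1 of the 3 values shown sits.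

Compound 4 `COc1ccccc1-c1nc(C)c(COc2cccc(C(=O)O)c2)o1` is not yet measured and follows from compound 2 by the same change, (hydrogen in place of methyl on an oxygen next to a carbonyl group). In this assay compound 4 is expected to move a 5.5-fold higher number from compound 2 to compound 4 (0.74 log units; beyond the scatter), because the matching change gave an at least 3.9-fold higher number from compound 1 to compound 3 (0.59 log units; beyond the scatter). For compound 4 the estimated value is 40000 nM, expected to fall between 15000 nM and 120000 nM.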

Compound 4, half-maximal inhibitory concentration: > 100000 nM
Compound 4 ended at the assay's limit (the forecaster's own chance of this, stated with the estimate: 30%); middle value at least 2.5-fold (0.39 log units) from the limit.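

In this assay, putting hydrogen in place of methyl on an oxygen next to a carbonyl group, which turns methoxycarbonyl to carboxy, gave an at least 13-fold higher number from compound 2 to compound 4 (1.13 log units; beyond the scatter). Compound 4 gives > 100000 nM, which is a limit of the assay and not a number. The change therefore carried over from one core to the other in direction, but this does not show that its size carried over: the same change on two cores in this assay, an at least 3.9-fold higher number (0.59 log units; beyond the scatter) from compound 1 to compound 3 and an at least 13-fold higher number (1.13 log units; beyond the scatter) from compound 2 to compound 4; the limit leaves it open whether they differ

The compounds shown leave open how an amide or an ethyl ester in place of the methoxycarbonyl group would read in this assay. They also leave open whether a carboxy compound on either core gives a number within the range of this assay at all.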